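This account rests on a few compounds, and the source may have more. Where it says the series, first, only, none or still open, it means among the compounds named here.

Measured so far in an ADME assay on HMEC-1 cells (Homo sapiens) for cytotoxicity, read by MTT assay, with a stated time of 72 h; on this read-out higher numbers stand for weaker inhibition and lower numbers for stronger inhibition:
compound 1 `Clc1ccc2c(NC[C@H]3CCCN4CCCC[C@@H]34)ccnc2c1`: > 60000 nM, a limit of the assay.
compound 2 `Clc1ccc2c(NC[C@@H]3CCCN4CCCC[C@H]34)ccnc2c1`: > 49000 nM, a limit of the assay.

Compound 2 thus stands only at a limit in this assay, with no measured number. Among the compounds with values here, the only measured step, a step that the two limits leave unreadable from compound 1 to compound 2, cannot be read because the limit of > 49000 nM in this assay, at which 1 of the 2 values shown sits, and the limit of > 60000 nM in this assay, at which 1 of the 2 values shown sits, are both limits, while the pair differ only as mirror images (the fact that compounds 1 and 2 differ only in the configuration as drawn). Compound 3 `Clc1ccc2c(NCC3CCCN4CCCCC34)ccnc2c1` differs from compound 2 as follows: the two compounds have the same atoms and bonds; at least one stereo element is drawn with a configuration in one of them and without one in the other: 2 of 2 stereo elements differ; a stereocentre at a saturated ring carbon is drawn S in compound 2 and without a configuration in compound 3; a stereocentre at a saturated ring carbon is drawn R in compound 2 and without a configuration in compound 3. Since both drawn configurations sit at limits, the step that the limit leaves unreadable from compound 2 to compound 3 is expected to be nothing beyond the scatter. Compound 3 is therefore estimated at 80000 nM, range 40000 nM to 300000 nM, most likely reported as a limit again.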

Compound 3, half-maximal inhibitory concentration: > 60000 nM
Compound 3: a limit, no number; the forecaster's own chance of this, stated with the estimate: 90%; the middle value is on the limit's open side.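

Compound 3 also stands only at a limit, so its steps to compound 1 and compound 2 cannot be read. The compounds shown leave open whether configuration changes the cytotoxicity of this series, since none has a measured number.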